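The compounds below may be only part of what the source reports. "The series", "measured", "known", "first", "only" and "open" are said of these compounds alone.

Measured compounds and their numbers in an assay on microsomes from liver for inhibition of 3-hydroxy-3-methylglutaryl-coenzyme A reductase (Rattus norvegicus); on this read-out higher numbers stand for weaker inhibition and lower numbers for stronger inhibition:

Compound 1, `CC(C)c1c(C(=O)N(C)Cc2cccc(F)c2)nn(-c2ccc(F)cc2)c1CC[C@@H](O)C[C@@H](O)CC(=O)O`, compound 1 gives 4.1 nM.
Compound 2, `CC(C)c1c(C(=O)NCC2CCCCC2)nn(-c2ccc(F)cc2)c1OC[C@@H](O)C[C@@H](O)CC(=O)O`, compound 2 gives 17 nM.
Compound 3, `CC(C)c1c(C(=O)N2CCC[C@H](N3CCC4C=CC=CC4C3)C2)nn(-c2ccc(F)cc2)c1CC[C@@H](O)C[C@@H](O)CC(=O)O`, compound 3 gives 10 nM.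

Among these three, compound 2 has the highest number. Its number lies within the usual scatter of that of compound 3, so the two cannot be told apart, while compound 1 sits clearly lower, beyond the scatter, and so inhibits more strongly than compound 2.

Compound 4, `Cc1cccc(CNC(=O)c2nn(-c3ccc(F)cc3)c(OC[C@@H](O)C[C@@H](O)CC(=O)O)c2C(C)C)c1`, has not yet been measured. It differs from compound 2 in one place: 3-methylphenyl in place of cyclohexyl on a saturated chain carbon bound to an amide-type nitrogen. All else in the structure stays the same. Within the data shown here, no measured pair shows this exact change, so the expected size of the step rests on the spread of the three numbers. The step from compound 2 to compound 4 is estimated as a 1.4-fold lower number from compound 2 to compound 4 (0.15 log units; within the scatter), a modest move toward a lower number, possibly not beyond the scatter. Compound 4 is therefore expected to give about 12 nM, with a likely range from 4 nM to 35 nM.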

Compound 4, half-maximal inhibitory concentration: 4.9 nM
The estimate for compound 4 lay 2.4-fold (0.39 log units) above the measured number; measured number inside the range.
By their numbers in this assay, from the lowest: compounds 1 and 4 (each within the scatter of the next); then compounds 3 and 2 (each within the scatter of the next).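

In this assay, among these compounds, the first comparison here that differs in only one place gives a 3.5-fold lower number from compound 2 to compound 4 (0.54 log units; beyond the scatter), so the group on the saturated chain carbon bound to the amide-type nitrogen clearly affects inhibition. Replacing cyclohexyl with 3-methylphenyl makes the ring aromatic and adds a methyl group in a single change, and this step cannot show how much each part contributes. Nothing available here explains why the number falls.

An unsubstituted phenyl group at this place would help separate the contribution of the aromatic ring from that of the methyl group. The compounds shown also leave open how a methoxy group or an amine on that ring would compare with the methyl group of compound 4.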